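A ring group exchanged on a shared core

A few compounds are considered here, and "the series" means these few. Any claim that something is new, unique, unknown or untested is made for them only; others in the source may bear on it.

Measured so far in a functional assay on A2780 cells (Homo sapiens) for inhibition; a higher number here means a weaker inhibitor, a lower number a stronger inhibitor
- Compound 1 `C[C@H](C(=O)Nc1cc(C2CC2)[nH]n1)c1ccc(N2Cc3ccccc3C2=O)cc1` gives 1020 nM
- Compound 2 `CC(C(=O)Nc1cc(C2CC2)[nH]n1)c1ccc(N2CCC(C(N)=O)C2=O)cc1` gives 5710 nM

Compound 2 has the higher number of the pair (5710 nM), which makes it the weaker inhibitor, and its gap to compound 1 (1020 nM) lies beyond the scatter. Compound 3 `CC(C(=O)Nc1cc(C2CC2)[nH]n1)c1ccc(-n2cnnc2O)cc1` keeps the rest of compound 2 but changes the group on an aromatic carbon, para to a large group (a group of 6 heavy atoms (2 carbon, 3 nitrogen, 1 oxygen; one five-membered aromatic ring with 3 hetero atoms) in place of a group of 9 heavy atoms (5 carbon, 2 nitrogen, 2 oxygen; one five-membered non-aromatic ring with 1 hetero atom), on an aromatic carbon). For the measured compounds named here, no two measured compounds differ in one place only, so the data give no direct guide to this change. In this assay only a small shift toward a lower number is expected, not clearly beyond the scatter. The estimated change is a 1.8-fold lower number from compound 2 to compound 3 (0.25 log units; within the scatter) (an expectation only). The estimate stays within the span set by compound 1 (1020 nM) and compound 2 (5710 nM). The expected value for compound 3 is 3200 nM (estimated range 1000 nM to 9000 nM).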

Compound 3, half-maximal inhibitory concentration: 8390 nM
Compound 3: middle estimate off by 2.6-fold (0.42 log units), on the low side; the measured number falls inside the stated range.
By their numbers in this assay, from the lowest: compound 1; then compounds 2 and 3 (each within the scatter of the next).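

For the compounds shown here, this is the first direct comparison at this position, on an aromatic carbon para to a large group: in this assay, placing a five-membered aromatic ring with 3 hetero atoms where compound 2 carries a five-membered non-aromatic ring with 1 hetero atom gives a 1.5-fold higher number from compound 2 to compound 3 (0.17 log units; within the scatter). For this one pair, then, a group of 6 heavy atoms and a group of 9 heavy atoms cannot be told apart in this assay, although one ring is aromatic and the other is not. No supporting measurement bears on this result.

As far as these compounds go, what a simple amine or a carboxylic acid at this same position would give in this assay stays open. Compound 1 differs from compound 2 and compound 3 in more than one place, so the part played by its own ring group also stays unresolved.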